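Replacing a phenyl with ethoxy on an aminothiophene ketone

A few compounds are considered here, and "the series" means these few. Any claim that something is new, unique, unknown or untested is made for them only; others in the source may bear on it.

Compounds measured so far in a functional assay on L1210 cells (Mus musculus) for antiproliferative activity; a lower number here means a stronger inhibitor, a higher number a weaker inhibitor:
- compound 1, `COc1cc(C(=O)c2sc(-c3ccc(-c4ccccc4)cc3)cc2N)cc(OC)c1OC`: > 10000 nM
- compound 2, `COc1cc(C(=O)c2sc(-c3ccc(I)cc3)cc2N)cc(OC)c1OC`: 400 nM
- compound 3, `COc1cc(C(=O)c2sc(-c3ccccc3Cl)cc2N)cc(OC)c1OC`: 20 nM

Compound 1 carries a phenyl on the outer aromatic ring. In this assay compound 1 reaches only the limit (the limit of > 10000 nM in this assay, at which 1 of the 3 values shown sits), so no number is known for it and it stands as the weakest of the three in this assay. Exchanging that phenyl for iodo gives an at least 25-fold lower number from compound 1 to compound 2 (1.39 log units; beyond the scatter), and moving to a 2-chlorophenyl in place of the 4-iodophenyl gives a further a 20-fold lower number from compound 2 to compound 3 (1.30 log units; beyond the scatter).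

The unmeasured compound 4, `CCOc1ccc(-c2cc(N)c(C(=O)c3cc(OC)c(OC)c(OC)c3)s2)cc1`, differs from compound 1 by a single change: ethoxy in place of phenyl on an aromatic carbon. This resembles the first step, where a bulky phenyl was exchanged for a smaller single substituent at the same place. That step was large and beyond the scatter, so a drop in the number in this assay of similar magnitude is expected for compound 4; the step from compound 1 to compound 4 is estimated as an at least 33-fold lower number from compound 1 to compound 4 (1.52 log units; beyond the scatter). In this assay compound 4 is therefore expected to give about 300 nM, most likely within the range from 50 nM to 3000 nM.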

Compound 4, half-maximal inhibitory concentration: 590 nM
For compound 4 the middle estimate is 2.0-fold (0.29 log units) below the measured one, within the range that was stated.
By their numbers in this assay, from the lowest: compound 3; then compounds 2 and 4 (each within the scatter of the next). At a limit, above all of these: compound 1.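

In this assay, ethoxy in place of phenyl gives an at least 16-fold lower number from compound 1 to compound 4 (1.22 log units; beyond the scatter), which shows that a second aromatic ring at this place is not needed for activity and that a small oxygen-linked chain can stand there instead. Compound 1 sits at a limit of the assay, so the true size of this step is not known: the limit of > 10000 nM in this assay, at which 1 of the 4 values shown sits. Ethoxy in place of iodo gives a 1.5-fold higher number from compound 2 to compound 4 (0.17 log units; within the scatter), so these two quite different substituents cannot be told apart at this place, whereas 4-ethoxyphenyl in place of 2-chlorophenyl gives a 30-fold higher number from compound 3 to compound 4 (1.47 log units; beyond the scatter), so the choice of substituted ring on the core still matters far more than the swap between iodo and ethoxy.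

The compounds shown leave open whether a methoxy, a longer chain such as butoxy, an amine or a carboxylic acid at this same place would give numbers like those of compounds 2 and 4. They also leave open how much of the gain in compound 3 comes from the chlorine itself and how much from where it sits, as the group and its place change together in that step.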